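Hydroxymethyl to carboxy on the arene of oxazolidinone imides

A few compounds are considered here, and "the series" means these few. Any claim that something is new, unique, unknown or untested is made for them only; others in the source may bear on it.

Compound 1 `O=C(CCCCCc1cccc(CO)c1)N1CCOC1=O` carries a hydroxymethyl on its arene. In an assay on HEK293 cells for inhibition of N-acylethanolamine-hydrolyzing acid amidase (Rattus norvegicus), read by LC-MS, with a stated time of 30 min (a higher number here means a weaker inhibitor, a lower number a stronger inhibitor), compound 1 gives only a limit, > 20000 nM. Compound 2 `O=C(O)c1cccc(CCCCCC(=O)N2CCOC2=O)c1` differs from it by carboxy in place of hydroxymethyl on an aromatic carbon. In this assay compound 2 likewise gives only a limit, > 20000 nM. The step that the two limits leave unreadable from compound 1 to compound 2 is thus unreadable, both values sitting at the limit of > 20000 nM in this assay, at which 2 of the 3 values shown sit. Compound 3 `O=C(CCCCCc1ccc(CO)cc1)N1CCOC1=O` has the same atoms as compound 1 joined differently; the difference between the two cores is not broken down here. In this assay, within the data shown here, compound 3 gives 190 nM, the one number in the set.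

Compound 4 `O=C(O)c1ccc(CCCCCC(=O)N2CCOC2=O)cc1` has not been measured. It makes the same kind of change as compound 1 to compound 2, namely (carboxy in place of hydroxymethyl on an aromatic carbon), though here the group sits para to a large group, where before it sat meta to a large group. Among the measured compounds shown here, the one measured instance of this change gives no readable size, so the expectation rests on compound 3 alone and is wide. Compound 4 is expected near 2000 nM in this assay. The expected step is an 11-fold higher number from compound 3 to compound 4 (1.02 log units; beyond the scatter). The expected range for compound 4 runs from 300 nM to 20000 nM.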

Compound 4, half-maximal inhibitory concentration: > 20000 nM
Compound 4: no number, only a limit (the forecaster's own chance of this, stated with the estimate: 25%); middle value at least 10-fold (1.00 log units) away from the limit.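

In this assay, carboxy in place of hydroxymethyl on an aromatic carbon para to a large group gives an at least 100-fold higher number from compound 3 to compound 4 (2.02 log units; beyond the scatter). Compound 4 gives only a limit, > 20000 nM, so this size is a lower bound on the step and not a measured number. The same change on the core of compound 1 cannot be read, since both of its ends are limits, so the series shows a large loss on one core only and does not show whether the change carries the same size from one core to the other, with most of the set sitting at one edge of the assay: the limit of > 20000 nM in this assay, at which 3 of the 4 values shown sit.

Open, going by these compounds, is how an amine or a methyl ester in place of hydroxymethyl on the core of compound 3 would read in this assay. Also open, on these data alone, is whether a longer chain would leave the carboxy step on that core as large as it stands here.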